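The source may hold more compounds than are shown below. What is called first, only, known or untested is meant among the compounds shown, and "the series" means these compounds.

Measured so far:
- compound 1 `CN1CCN(CCCCn2c3c(c4ccccc42)C(=O)c2c[n+]([O-])c4ccccc4c2C3=O)CC1`: 110 nM
- compound 2 `CC1(C)O[C@@H](CO)[C@H](Cn2cc(Cn3c4c(c5ccccc53)C(=O)c3c[n+]([O-])c5ccccc5c3C4=O)nn2)O1`: 680 nM
- compound 3 `CC1(C)OC[C@H](Cn2cc(Cn3c4c(c5ccccc53)C(=O)c3c[n+]([O-])c5ccccc5c3C4=O)nn2)O1`: 530 nM

All three values come from a functional assay on MDA-MB-231 cells (Homo sapiens) for cytotoxicity, read by MTT assay, with a stated time of 72 h; a lower number here means a stronger inhibitor, a higher number a weaker inhibitor. Compound 1 holds the lowest number of the three, and the gaps to compound 2 and compound 3 lie beyond the scatter.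

Compound 4 `CN1CCN(CCCn2c3c(c4ccccc42)C(=O)c2c[n+]([O-])c4ccccc4c2C3=O)CC1` differs from compound 1 by 4-methylpiperazin-1-yl in place of (4-methylpiperazin-1-yl)methyl on a saturated chain carbon, three bonds along the chain from an aromatic nitrogen, on a saturated chain carbon, three bonds along the chain from an aromatic nitrogen. Going by the values given here, the one measured step, a 1.3-fold lower number from compound 2 to compound 3 (0.11 log units; within the scatter), lies within the scatter but concerns a saturated ring carbon, so it bears only weakly on this chain change. No step beyond the scatter is therefore expected in this assay, and the expected step is a 1.3-fold higher number from compound 1 to compound 4 (0.10 log units; within the scatter). For compound 4 the estimated value is 140 nM, with an expected range of 50 nM to 400 nM.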

Compound 4, half-maximal inhibitory concentration: 390 nM
Compound 4: middle estimate off by 2.8-fold (0.44 log units), on the low side, within the range that was stated.
By their numbers in this assay, from the lowest: compound 1; then compounds 4, 3 and 2 (each within the scatter of the next).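

In this assay, going by these compounds alone, going from 4-(4-methylpiperazin-1-yl)butyl to 3-(4-methylpiperazin-1-yl)propyl gives a 3.5-fold higher number from compound 1 to compound 4 (0.55 log units; beyond the scatter), the first one-place change to lie beyond the scatter. At this chain position, then, the length of the chain carrying the same 4-methylpiperazin-1-yl group registers in the read-out, with the butyl chain giving the lower number of the pair. No supporting data bear on the origin of this step.

Going by these compounds, whether a longer chain, such as 5-(4-methylpiperazin-1-yl)pentyl, would lower the number further remains open. So does whether a morpholine in place of the 4-methylpiperazin-1-yl group would hold the value of the butyl compound.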